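Cytotoxicity of a nitro thiochromenone series: a fluorophenyl analogue

The source may report more compounds than this note shows. Statements on the series, on what has been measured and on what is new or still open speak of the compounds shown alone.

Measured compounds:
Compound 1, `O=c1cc(NCc2ccccc2)sc2c([N+](=O)[O-])cc(C(F)(F)F)cc12`, gives > 64 ug/mL in an ADME assay on Vero cells (Chlorocebus sabaeus) for cytotoxicity, read by MTT assay, with a stated time of 48 h (on this read-out lower numbers stand for stronger inhibition and higher numbers for weaker inhibition), which is a limit of the assay.
Compound 2, `O=c1cc(NCc2ccc3c(c2)OCCO3)sc2c([N+](=O)[O-])cc(C(F)(F)F)cc12`, gives > 64 ug/mL in this assay, again a limit of the assay.

Compound 2 therefore stands at the limit shared by both measured values, (the limit of > 64 ug/mL in this assay, at which 2 of the 2 values shown sit), with no number of its own. Within the data shown here, the one measured step, a step that the two limits leave unreadable from compound 1 to compound 2, cannot be read because both values are limits. Compound 3, `O=c1cc(NCc2cccc(F)c2)sc2c([N+](=O)[O-])cc(C(F)(F)F)cc12`, differs from compound 2 by 3-fluorophenyl in place of 2,3-dihydro-1,4-benzodioxin-6-yl on a saturated chain carbon bound to a nitrogen on an aromatic ring. Among the measured compounds shown here, no measured step bears on this change in a readable way, so the expectation rests only on both values sitting at the limit. The step that the limit leaves unreadable from compound 2 to compound 3 is expected to show nothing beyond the scatter, since both measured compounds sit at the limit (the limit of > 64 ug/mL in this assay, at which 2 of the 2 values shown sit). Compound 3 is estimated at 90 ug/mL, between 40 ug/mL and 250 ug/mL, most likely reported again as a limit in this assay.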

Compound 3, half-maximal inhibitory concentration: > 64 ug/mL
Compound 3 gave a limit, no number; the forecaster's own chance of this, stated with the estimate: 80%; the middle value does not contradict the limit.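

Compound 3 gives > 64 ug/mL in this assay as a limit of the assay. Among these compounds, no step among compound 1, compound 2 and compound 3 can be read, as all three sit at one limit: the limit of > 64 ug/mL in this assay, at which 3 of the 3 values shown sit.

The compounds shown leave open what concentration, if any, gives half-maximal inhibition in this assay for any of them.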